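Working notes: ring-nitrogen substituent in a biaryl imidazole series

The source may report more compounds than this note shows. Statements on the series, on what has been measured and on what is new or still open speak of the compounds shown alone.

compound 1 `COC(=O)c1ccccc1-c1ccc(CCc2ncc(CC(C)(C)C)n2CC(=O)O)cc1` — 968 nM
compound 2 `CC(C)(C)Cc1cnc(CCc2ccc(-c3ccccc3C(=O)O)cc2)n1CC(=O)O` — 897 nM

Both compounds were measured in an assay on cells for agonist activity at Bombesin receptor subtype-3 (Homo sapiens), read by HTRF and inositol phosphate accumulation, with a stated time of 1 h; a higher number here means that more compound is needed for the effect, a lower number that less compound is needed; compound 1 gives 968 nM and compound 2 gives 897 nM. Compound 1 has the highest of the two numbers; its nearest neighbour is compound 2, with the step of a 1.1-fold lower number from compound 1 to compound 2 (0.03 log units; within the scatter), which rests on hydrogen in place of methyl on an oxygen next to a carbonyl group.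

Compound 3 `COC(=O)c1ccccc1-c1ccc(CCc2ncc(CC(C)(C)C)[nH]2)cc1` is not yet measured. It differs from compound 1 by hydrogen in place of carboxymethyl on an aromatic nitrogen. Going by the values given here, no measured step touches this part of the molecule; the only step available, from compound 1 to compound 2, concerns the ester and is within the scatter, so it gives no guide to the size or direction of the change here. The expectation for compound 3 is therefore weakly held: a step of a 3.1-fold higher number from compound 1 to compound 3 (0.49 log units; beyond the scatter) is estimated, with a wide range around it. Compound 3 is expected at 3000 nM, between 600 nM and 15000 nM.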

Compound 3, half-maximal effective concentration: 644 nM
Beside the measured number, compound 3's estimate is 4.7-fold (0.67 log units) above it, within the range that was stated.
By their numbers in this assay, from the lowest: compounds 3, 2 and 1 (each within the scatter of the next).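

In this assay the carboxymethyl group on the aromatic nitrogen gives way to hydrogen with no change beyond the scatter (a 1.5-fold lower number from compound 1 to compound 3 (0.18 log units; within the scatter)). Going by these compounds alone, the earlier step spoke only to the ester, so this is the only reading at the nitrogen, and it shows that, with the methyl ester of compound 1 in place, the number in this assay does not depend on the carboxymethyl group. Nothing at hand bears on why the two compounds read alike.

On these data alone, whether hydrogen on this nitrogen is equally accepted alongside the free carboxylic acid of compound 2 remains open. So does the effect of other groups at the same nitrogen, such as a methyl group, a longer carboxyethyl chain or a primary amide on the same chain.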